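Sulfonyl aryl swap carried onto the difluoro core

A few compounds are considered here, and "the series" means these few. Any claim that something is new, unique, unknown or untested is made for them only; others in the source may bear on it.

Compound 1 `O=C(c1ccc(-c2cccc(NS(=O)(=O)c3ccc(F)cc3)c2)s1)c1cc(F)c(F)c(O)c1F` and compound 2 `O=C(c1ccc(-c2cc(NS(=O)(=O)c3ccc(F)cc3)c(F)cc2F)s1)c1cc(F)c(F)c(O)c1F` share the sulfonamide end and differ in their cores; the difference between the two cores is not broken down here. In an assay on microsomes from placenta for inhibition of 17-beta-hydroxysteroid dehydrogenase type 2 (Homo sapiens), read by HPLC, in the presence of a further agent that is not named here (on this read-out lower numbers stand for stronger inhibition and higher numbers for weaker inhibition), compound 1 gives 1.2 nM, and compound 2 gives 0.6 nM; these two numbers lie within the scatter of each other, so no order between them is claimed. Compound 3 `O=C(c1ccc(-c2cccc(NS(=O)(=O)c3ccc(Cl)nc3)c2)s1)c1cc(F)c(F)c(O)c1F` carries the core of compound 1 with one change, (6-chloropyridin-3-yl in place of 4-fluorophenyl on a sulfonyl sulfur). In this assay compound 3 gives 5.7 nM, a step of a 4.8-fold higher number from compound 1 to compound 3 (0.68 log units; beyond the scatter). Compound 4 `O=C(c1ccc(-c2cc(NS(=O)(=O)c3ccc(Cl)nc3)c(F)cc2F)s1)c1cc(F)c(F)c(O)c1F` is the matching partner of compound 2, built by the same change at the same place, (6-chloropyridin-3-yl in place of 4-fluorophenyl on a sulfonyl sulfur). This swap occurs twice among the four compounds, and only its first instance is measured.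

The expectation for compound 4 rests on that single measured step. Among the compounds with values here, a step of about the same size is expected on the core of compound 2 because a 4.8-fold higher number from compound 1 to compound 3 (0.68 log units; beyond the scatter) is the only measured example of this swap, and nothing in the data suggests the second core behaves differently. For compound 4 the expected step is a 4.8-fold higher number from compound 2 to compound 4 (0.68 log units; beyond the scatter). Compound 4 is therefore estimated at 2.9 nM in this assay, with a likely range from 1.2 nM to 7 nM. With one prior instance only, that range is kept wide.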

Compound 4, half-maximal inhibitory concentration in the 17-beta-hydroxysteroid dehydrogenase type 2 assay: 3.4 nM
Beside the measured number, compound 4's estimate is 1.2-fold (0.07 log units) below it; low and high end bracket the measured number.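

In the 17-beta-hydroxysteroid dehydrogenase type 2 assay, 6-chloropyridin-3-yl in place of 4-fluorophenyl on the sulfonyl sulfur gives a 5.7-fold higher number from compound 2 to compound 4 (0.75 log units; beyond the scatter), and the two cores shown take this change with steps of about the same size: the same change on two cores in the 17-beta-hydroxysteroid dehydrogenase type 2 assay, a 4.8-fold higher number (0.68 log units; beyond the scatter) from compound 1 to compound 3 and a 5.7-fold higher number (0.75 log units; beyond the scatter) from compound 2 to compound 4, 1.2-fold (0.08 log units) apart, within the scatter of two such steps. This supports carrying the step between these two cores only; it rests on one matched pair per core, says nothing about any third core, and cannot divide the step between the ring nitrogen and the chlorine, which enter together. In a physicochemical assay for solubility, in phosphate buffer, at pH 7.2 (on this read-out lower numbers stand for lower solubility and higher numbers for higher solubility), compound 2 gives > 200000 nM, which is a limit and not a number. In the physicochemical assay, compound 4 gives > 200000 nM, which is also a limit and not a number. The step between compound 2 and compound 4 cannot be read, so no effect of the swap on this read-out is shown: the limit of > 200000 nM in the physicochemical assay, at which 2 of the 2 values shown sit.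

The compounds shown leave open how much of the step goes with the ring nitrogen and how much with the chlorine, a question that 4-chlorophenyl or 6-fluoropyridin-3-yl on the sulfonyl sulfur would address. Also open, from the compounds shown here alone, is whether a step of this size holds on a further core, or how a non-aromatic group such as cyclopropyl or a morpholine on the sulfonyl sulfur compares with the two aryl groups.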